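A few compounds are considered here, and "the series" means these few. Any claim that something is new, unique, unknown or untested is made for them only; others in the source may bear on it.

Compound 1 `COc1ccccc1/C=C1\CCC/C(=C\c2ccc(OC)c(OC)c2)C1=O`: 7800 nM
Compound 2 `COc1ccc(/C=C2\CCC/C(=C\c3cc(Cl)cc(Cl)c3)C2=O)cc1OC`: 2500 nM

Both values come from a functional assay on SW-620 cells (Homo sapiens) for cytotoxicity, read by MTT assay, with a stated time of 72 h; a higher number here means a weaker inhibitor, a lower number a stronger inhibitor. Of the two compounds, compound 2 has the lower number at 2500 nM, which makes it the stronger inhibitor of the pair.

Compound 3 `COc1ccc(/C=C2\CCC/C(=C\c3ccc(O)c(O)c3)C2=O)cc1OC` keeps the shared core and alters a single group: 3,4-dihydroxyphenyl in place of 3,5-dichlorophenyl on a double-bonded chain carbon bound to a double-bonded ring carbon. The 3,4-dihydroxyphenyl group takes the place of the 3,5-dichlorophenyl group on a double-bonded chain carbon bound to a double-bonded ring carbon. For the measured compounds named here, only one measured step bears on this change, and it falls at the same place: a 3.1-fold lower number from compound 1 to compound 2 (0.49 log units; beyond the scatter). That step is modest. Neither of its two groups is the one now entering, so it gives a sense of size but no direction. Going by the values given here, no measured compound carries a 3,4-dihydroxyphenyl group at this place. A modest shift either way is therefore possible, and the central expectation in this assay is no change beyond the scatter. The expected change is a 1.1-fold higher number from compound 2 to compound 3 (0.05 log units; within the scatter). For compound 3 the estimated value is 2800 nM, with an expected range from 700 nM to 9000 nM.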

Compound 3, half-maximal inhibitory concentration: 10500 nM
For compound 3 the middle estimate is 3.8-fold (0.57 log units) below the measured one, and the stated range ends below it.
By their numbers in this assay, from the lowest: compound 2; then compounds 1 and 3 (each within the scatter of the next).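

In this assay the exchange of 3,5-dichlorophenyl for 3,4-dihydroxyphenyl on a double-bonded chain carbon bound to a double-bonded ring carbon gives a 4.2-fold higher number from compound 2 to compound 3 (0.62 log units; beyond the scatter) and so supplies what the earlier step could not, a direction for a group with hydroxyl oxygens in place of chlorine atoms. Against 2-methoxyphenyl at the same place, the entering group gives a 1.3-fold higher number from compound 1 to compound 3 (0.13 log units; within the scatter) and the two oxygen-bearing groups cannot be told apart in this assay, which leaves 3,5-dichlorophenyl as the only one of the three groups whose number stands apart from the others. Nothing at hand accounts for this difference.

As far as these compounds go, whether the higher number of compound 3 goes with the arrival of the hydroxyl groups or with the departure of the chlorine atoms stays open, since the two happen in one step. Also open, from the compounds shown here alone, is how a plain phenyl, a single chlorine atom, a single hydroxyl group or an amine on the ring would compare at this place, and whether the order of these groups would hold with a different group on the other double-bonded chain carbon.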